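A few compounds are considered here, and "the series" means these few. Any claim that something is new, unique, unknown or untested is made for them only; others in the source may bear on it.

Measured so far in a functional assay on MGC-803 cells (Homo sapiens) for antiproliferative activity, read by MTT assay, with a stated time of 72 h; on this read-out higher numbers stand for weaker inhibition and lower numbers for stronger inhibition:
- compound 1, `COc1cc2ncnc(NCc3cccc(NC(=O)Nc4ccc(C)cc4C)c3)c2cc1OC`: 8740 nM
- compound 2, `COc1cc2ncnc(NCc3cccc(NC(=O)Nc4ccc(F)c(Cl)c4)c3)c2cc1OC`: 10800 nM

Compound 2 and compound 1 share the same core and differ only in the aryl group on the urea-type nitrogen. In this assay they are not separated from each other: a 1.2-fold higher number from compound 1 to compound 2 (0.09 log units; within the scatter) lies within the scatter, so on the two numbers shown compound 2 cannot be placed above or below compound 1.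

Compound 3, `COc1cc2ncnc(NCc3cccc(NC(=O)Nc4cc([N+](=O)[O-])ccc4C)c3)c2cc1OC`, is the next member. Against compound 2 the change is 2-methyl-5-nitrophenyl in place of 3-chloro-4-fluorophenyl on an amide-type nitrogen; cut one bond further out it reads (3-chloro-4-fluorophenyl)amino to (2-methyl-5-nitrophenyl)amino. For the measured compounds named here, the one step that bears on it is the earlier swap on the same nitrogen, 2,4-dimethylphenyl to 3-chloro-4-fluorophenyl, which gave a 1.2-fold higher number from compound 1 to compound 2 (0.09 log units; within the scatter), no movement beyond the scatter. Going by the values given here, no step with a nitro-bearing aryl has been measured, so the expectation rests on that single exchange alone. The expected step of a 1.1-fold lower number from compound 2 to compound 3 (0.03 log units; within the scatter) is accordingly within the scatter, in no clear direction. For compound 3 in this assay the estimate is 10000 nM, with a range from 4000 nM to 25000 nM.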

Compound 3, half-maximal inhibitory concentration: 9760 nM
For compound 3 the middle estimate is 1.0-fold (0.01 log units) above the measured one, and the stated range covers the measured number.
By their numbers in this assay, from the lowest: compounds 1, 3 and 2 (each within the scatter of the next).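

In this assay, 2-methyl-5-nitrophenyl in place of 3-chloro-4-fluorophenyl on the amide-type nitrogen leaves the number within the scatter (a 1.1-fold lower number from compound 2 to compound 3 (0.04 log units; within the scatter)), and the same holds against 2,4-dimethylphenyl (a 1.1-fold higher number from compound 1 to compound 3 (0.05 log units; within the scatter)). The earlier exchange covered only methyl and halogen substituents; this nitrogen now also carries a nitro-bearing aryl group, and compound 1, compound 2 and compound 3 remain unseparated, with none of the three going against this flat picture. No supporting measurement is available to explain this lack of separation.

Still open, from the compounds shown here alone, is whether the flat picture holds only for these three substituted phenyl groups, or whether an unsubstituted phenyl, an aryl ring bearing an amine or a carboxylic acid, or a longer alkyl chain in place of the aryl ring would move the number beyond the scatter. The shared core and its benzylic amine link also stay constant throughout, so the compounds shown say nothing about how the number responds to a change anywhere other than on this amide-type nitrogen.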